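Trifluoromethyl for methyl on the sulfonamide of compound 3

This account rests on a few compounds, and the source may have more. Where it says the series, first, only, none or still open, it means among the compounds named here.

The series shares one core, a benzamide carrying a sulfonamide on the aniline ring. Compound 1 `Cc1cc(NC(=O)c2ccc(C#N)cc2)ccc1NS(=O)(=O)C(F)(F)F` bears a (trifluoromethyl)sulfonyl group, a methyl and a nitrile. Compound 2 `CS(=O)(=O)Nc1ccc(NC(=O)c2ccc(Cl)cc2)cc1F` bears a methylsulfonyl group, a fluorine and a chlorine. Compound 3 `CS(=O)(=O)Nc1ccc(NC(=O)c2ccc(C#N)cc2)cc1F` bears a methylsulfonyl group, a fluorine and a nitrile. In an ADME assay on RAW264.7 cells (Mus musculus) for cytotoxicity, read by MTT assay, with a stated time of 48 h (a higher number here means a weaker inhibitor, a lower number a stronger inhibitor), compound 1 gives 135000 nM. In this assay compound 2 gives 22300 nM. In this assay compound 3 reaches only the limit of the assay, > 250000 nM, so no number is known for it; it is the one of the three that sits at the limit of > 250000 nM in this assay, at which 1 of the 3 values shown sits. Going by the values given here, the sole measured step, an at least 11-fold higher number from compound 2 to compound 3 (1.04 log units; beyond the scatter), moves in the direction of weaker inhibition.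

Compound 4 `N#Cc1ccc(C(=O)Nc2ccc(NS(=O)(=O)C(F)(F)F)c(F)c2)cc1` differs from compound 3 by trifluoromethyl in place of methyl on a sulfonyl sulfur. Among the compounds with values here, no measured pair shows this change, so the step is not directly covered. Compound 1, which carries the same (trifluoromethyl)sulfonyl group and nitrile, gives a number rather than a limit, which suggests compound 4 is expected to return to a measurable value. The step of an at least 1.6-fold lower number from compound 3 to compound 4 (0.22 log units; that floor lies within the scatter) is therefore expected to be modest and toward stronger inhibition. Compound 4 is estimated at 150000 nM, with a range from 60000 nM to 300000 nM.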

Compound 4, half-maximal inhibitory concentration: > 250000 nM
Compound 4: only a limit was reported (the forecaster's own chance of this, stated with the estimate: 40%); middle value at least 1.6-fold (0.22 log units) from the limit.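

In this assay compound 4 gives only a limit, > 250000 nM. Going by these compounds alone, compound 3 also stands at a limit, so the step between the two cannot be read, and the change from methyl to trifluoromethyl on the sulfonyl sulfur shows no size or direction; what it does show is that this change, with the nitrile and the fluoro kept, does not bring a number inside the range of the assay: the limit of > 250000 nM in this assay, at which 2 of the 4 values shown sit. The one step that can be read is an at least 1.8-fold higher number from compound 1 to compound 4 (0.26 log units; that floor lies within the scatter), for fluoro in place of methyl on an aromatic carbon, so with the trifluoromethyl group held constant this floor alone does not establish a real change, although the true difference could be larger.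

The compounds shown leave open whether chloro in place of nitrile would bring a measurable number with trifluoromethyl on the sulfonyl sulfur, as compound 2 has with methyl there. They also leave open how a longer chain such as ethyl, or an amine, on the sulfonyl sulfur would read in this assay.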